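Repeating a Fluoro Step on Compound 3

A few compounds are considered here, and "the series" means these few. Any claim that something is new, unique, unknown or untested is made for them only; others in the source may bear on it.

Three compounds have been measured in an assay on isolated protein for inhibition of Indoleamine 2,3-dioxygenase 1 (Homo sapiens), read by spectrophotometry; on this read-out higher numbers stand for weaker inhibition and lower numbers for stronger inhibition:

Compound 1 `O/N=C(/Nc1cccc(C(F)(F)F)c1)c1ccc2occc2c1` gives 1200 nM.
Compound 2 `O/N=C(/Nc1ccc(F)c(C(F)(F)F)c1)c1ccc2occc2c1` gives 1200 nM.
Compound 3 `O/N=C(/NCc1cccc(Cl)c1)c1ccc2occc2c1` gives only a limit, > 30000 nM, and not a number.

Compound 1 and compound 2 share a core and differ by fluoro in place of hydrogen on an aromatic carbon. That change gave no change at the digits printed from compound 1 to compound 2 (within the scatter). So in this pair the added fluoro left the inhibition where it was.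

Compound 3 carries a different core, and the difference between the two cores is not broken down here. Compound 3 stands at the limit of > 30000 nM in this assay, at which 1 of the 3 values shown sits.

Compound 4 `O/N=C(/NCc1ccc(F)c(Cl)c1)c1ccc2occc2c1` has not been measured. It differs from compound 3 by fluoro in place of hydrogen on an aromatic carbon. Going by the values given here, this is the same kind of change as the one from compound 1 to compound 2, though not the same: in the earlier pair the fluoro enters ortho to a trifluoromethyl group, while here it enters ortho to a chloro group; in both it sits para to a large group.

Among the compounds with values here, the one measured example of this change showed no shift beyond the scatter. The step from compound 3 to compound 4 is therefore expected to be a step that the limit leaves unreadable from compound 3 to compound 4, resting on the flat step from compound 1 to compound 2 in this assay. Since compound 3 gives only a limit, compound 4 is estimated to land at about 40000 nM, most likely again reported as a limit rather than a number, with a range of 12000 nM to 120000 nM.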

Compound 4, half-maximal inhibitory concentration: 22000 nM
For compound 4 the middle estimate is 1.8-fold (0.26 log units) above the measured one; the measured number falls inside the stated range.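

Putting fluoro in place of hydrogen on an aromatic carbon gives an at least 1.3-fold lower number from compound 3 to compound 4 (0.13 log units; that floor lies within the scatter) in this assay, and this small floor is all that the pair can establish about the size of the step. Compound 3 has only a limit and not a number, so the true step could be small or much larger, and the pair cannot fix its size: the limit of > 30000 nM in this assay, at which 1 of the 4 values shown sits. Set beside the earlier pair, the result neither shows that the change carries over from one core to the other with the same effect nor shows that the two cores respond differently: the same change on two cores in this assay, no change at the digits printed (within the scatter) from compound 1 to compound 2 and an at least 1.3-fold lower number (0.13 log units; that floor lies within the scatter) from compound 3 to compound 4; the limit leaves it open whether they differ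

The compounds shown leave open how other groups would behave in the place taken by the fluoro, such as a nitrile, a methoxy group or an amine, on either core. They also leave open whether a measured number in place of the limit for compound 3 would bring this step closer to the earlier one or set it further apart.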